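The compounds below may be only part of what the source reports. "The series", "measured", "known", "first", "only" and "open" are said of these compounds alone.

Within the amide series compound 3 `Cc1cc(C)cc(C(=O)Nc2cccc(/C=C/C(=O)c3nc4ccccc4[nH]3)c2)c1` gives the lowest of the three numbers in a functional assay on HCT-116 cells (Homo sapiens) for antiproliferative activity, read by MTT assay, with a stated time of 48 h (on this read-out lower numbers stand for stronger inhibition and higher numbers for weaker inhibition), at 1550 nM; compound 2 `O=C(Nc1cccc(/C=C/C(=O)c2nc3ccccc3[nH]2)c1)c1cc(Cl)cc(Cl)c1` gives 1650 nM, a gap that lies within the scatter, while compound 1 `COc1cccc(C(=O)Nc2cccc(/C=C/C(=O)c3nc4ccccc4[nH]3)c2)c1` gives 3680 nM, and a 2.4-fold lower number from compound 1 to compound 3 (0.38 log units; beyond the scatter). Compound 4 `O=C(/C=C/c1cccc(NS(=O)(=O)c2ccc(Cl)cc2)c1)c1nc2ccccc2[nH]1` changes the linkage itself: (4-chlorophenyl)sulfonyl in place of (3,5-dimethylphenyl)carbonyl on a nitrogen on an aromatic ring. For the measured compounds named here, no measured step bears directly on this exchange; the steps of a 2.2-fold lower number from compound 1 to compound 2 (0.35 log units; beyond the scatter), a 2.4-fold lower number from compound 1 to compound 3 (0.38 log units; beyond the scatter) and a 1.1-fold lower number from compound 2 to compound 3 (0.03 log units; within the scatter) only vary the ring on the carbonyl carbon, and all are modest or within the scatter. With that narrow precedent the expectation for a 1.2-fold higher number from compound 3 to compound 4 (0.06 log units; within the scatter) is no step beyond the scatter, with wide uncertainty. The estimate for compound 4 in this assay is 1800 nM, in the range 500 nM to 6500 nM.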

Compound 4, half-maximal inhibitory concentration: 1960 nM
Estimate against measurement, compound 4: 1.1-fold (0.04 log units) below; the range from low to high includes it.
By their numbers in this assay, from the lowest: compounds 3, 2, 4 and 1 (each within the scatter of the next, the first and the last beyond it).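

In this assay, the carbonyl linkage on the nitrogen gives way to a sulfonyl linkage, carrying a different ring, with no step beyond the scatter: a 1.3-fold higher number from compound 3 to compound 4 (0.10 log units; within the scatter), a 1.2-fold higher number from compound 2 to compound 4 (0.07 log units; within the scatter) and a 1.9-fold lower number from compound 1 to compound 4 (0.27 log units; within the scatter). The position therefore accepts more than the amide, at least with the (4-chlorophenyl)sulfonyl group of compound 4. No evidence at hand explains this tolerance.

Linkage and ring change together in all three steps, so their separate contributions remain open. Also open, on these data alone, is whether a methylsulfonyl group, or a ring bearing an amine or a carboxylic acid, would fit this position.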